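The source may hold more compounds than are shown below. What is called first, only, known or untested is meant among the compounds shown, and "the series" means these compounds.

Measured so far:
- compound 1, `CCc1cnc(N2CCC(CCCNc3ccc4c(c3)OCC4=O)CC2)nc1`: 115%
- compound 2, `COC(=O)c1cnc(N2CCC(CCCNc3ccc4c(c3)OCC4=O)CC2)nc1`: 85%

In a functional assay on CHO-K1 cells for agonist activity at Glucose-dependent insulinotropic receptor (Homo sapiens), read by HTRF and cAMP accumulation, with a stated time of 30 min (on this read-out lower numbers stand for smaller maximal responses and higher numbers for larger maximal responses), compound 1 gives 115%, and compound 2 gives 85%. Going by the values given here, compound 2 stands at the lower of the two numbers: the one step that is known, a number 30 percentage points lower from compound 1 to compound 2 (beyond the scatter), is beyond the scatter but modest.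

The next compound, compound 3, `CC(C)c1nc(N2CCC(CCCNc3ccc4c(c3)OCC4=O)CC2)no1`, differs from compound 2 by 5-isopropyl-1,2,4-oxadiazol-3-yl in place of 5-(methoxycarbonyl)pyrimidin-2-yl on an amine nitrogen in a ring. Among the compounds with values here, the only measured step concerns a substituent change on the ring that leaves, not an exchange of the whole ring, so it bears on the present change only loosely; there is no measured pair that exchanges one heteroaryl ring on the amine nitrogen in a ring for another. The known step was modest in size, and nothing here points to a larger effect for the ring exchange. The expectation for compound 3 is therefore a step of a number 10 percentage points higher from compound 2 to compound 3 (within the scatter) that may fall within the scatter or be modest in either direction. The estimate for compound 3 in this assay is 95%, with a range from 70% to 120%.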

Compound 3, largest response reached (Emax), in percent of the reference or control that the assay uses: 91%
For compound 3 the middle estimate is 4 percentage points above the measured one; the measured number falls inside the stated range.
By their numbers in this assay, from the lowest: compounds 2 and 3 (each within the scatter of the next); then compound 1.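

In this assay, the whole heteroaryl ring on the amine nitrogen in a ring can be exchanged without a step that can be told from the scatter: 5-isopropyl-1,2,4-oxadiazol-3-yl in place of 5-(methoxycarbonyl)pyrimidin-2-yl gives a number 6 percentage points higher from compound 2 to compound 3 (within the scatter), so one five-membered aromatic ring with 3 hetero atoms and one six-membered aromatic ring with 2 hetero atoms are not separated here. Set against the 5-ethylpyrimidin-2-yl group, the same entering group gives a number 24 percentage points lower from compound 1 to compound 3 (beyond the scatter), which leaves compound 1 as the only one of the three whose steps to both others lie beyond the scatter. No measurement in hand gives a reason for either step.

Ring and substituent remain tangled, since the step between compound 1 and compound 3 changes both at once, and a 5-isopropylpyrimidin-2-yl group at the same place would show which of the two carries it. Also open, from the compounds shown here alone, is how far the maximal response follows the substituent on the ring that bears it, for instance with a carboxylic acid or an amine there in place of ethyl or methoxycarbonyl.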